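From 1H-indol-3-yl to 4-chlorophenyl on the saturated chain carbon

A few compounds are considered here, and "the series" means these few. Any claim that something is new, unique, unknown or untested is made for them only; others in the source may bear on it.

In a functional assay on DU-145 cells (Homo sapiens) for inhibition, read by trypan blue exclusion, with a stated time of 96 h (on this read-out higher numbers stand for weaker inhibition of growth and lower numbers for stronger inhibition of growth), compound 1 (`Cc1ccc(C)c(/C=C(\C(=O)c2ccc(Cl)cc2)S(=O)(=O)c2ccc(Br)cc2)c1`) gives 1000 nM and compound 2 (`O=C(/C(=C/c1ccc(Cl)cc1)Cc1c[nH]c2ccccc12)c1ccc(Cl)cc1Cl`) gives 10000 nM as the higher of the two numbers, a gap beyond the scatter. Going by the values given here, these two compounds differ in more than one place, so no single-change step is available as a guide. Compound 3 (`O=C(/C(=C/c1ccc(Cl)cc1)Cc1ccc(Cl)cc1)c1ccc(Cl)cc1Cl`) carries one change from compound 2 (4-chlorophenyl in place of 1H-indol-3-yl on a saturated chain carbon bound to a double-bonded chain carbon): 4-chlorophenyl in place of 1H-indol-3-yl on a saturated chain carbon bound to a double-bonded chain carbon. Among the compounds with values here, no measured step covers this exchange, so the expectation in this assay is only a modest shift toward stronger inhibition of growth, possibly none beyond the scatter. The estimated 2.0-fold lower number from compound 2 to compound 3 (0.30 log units; within the scatter) is therefore small and uncertain in size. Compound 3 is expected at 5000 nM (estimated range 1500 nM to 15000 nM).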

Compound 3, concentration for 50% growth inhibition: 10000 nM
Compound 3: middle estimate off by 2.0-fold (0.30 log units), on the low side; the measured number falls inside the stated range.
By their numbers in this assay, from the lowest: compound 1; then compounds 2 and 3 (each within the scatter of the next).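

In this assay, going by these compounds alone, the first single-change reading puts 4-chlorophenyl in place of 1H-indol-3-yl on a saturated chain carbon bound to a double-bonded chain carbon, and the step reads no change at the digits printed from compound 2 to compound 3 (within the scatter). At this place, then, the read-out holds when the five-membered aromatic ring and its hydrogen-bond donor leave and a single six-membered aromatic ring carrying chlorine enters, so neither feature is needed to keep the number where it stands. Nothing available explains this outcome.

As far as these compounds go, whether an amine or a carboxylic acid at this saturated chain carbon would move the number remains open. Compound 1 differs from compound 2 in more than one place, so its gap to them cannot be assigned to any single part of the structure.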